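Extending the amide aryl group of compound 2

This account rests on a few compounds, and the source may have more. Where it says the series, first, only, none or still open, it means among the compounds named here.

Measured in an ADME assay on BaF3 cells (Mus musculus) for antiproliferative activity, read by CCK-8 assay, with a stated time of 72 h; on this read-out lower numbers stand for stronger inhibition of growth and higher numbers for weaker inhibition of growth:
- Compound 1 `O=C(CCSc1ccc2c(/C=C/c3ccccn3)n[nH]c2c1)Nc1cccc(F)c1`: 6590 nM
- Compound 2 `Cc1ccc(NC(=O)CCSc2ccc3c(/C=C/c4ccccn4)n[nH]c3c2)cc1C(F)(F)F`: 530 nM

Of these two, compound 2 gives the lower number, at 530 nM. The next entry is compound 3 `CC1CCN(Cc2ccc(NC(=O)CCSc3ccc4c(/C=C/c5ccccn5)n[nH]c4c3)cc2C(F)(F)F)CC1`, which carries 4-methylpiperidin-1-yl in place of hydrogen on a saturated chain carbon bound to an aromatic carbon.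

Among the measured compounds shown here, one measured step bears on this change: a 12-fold lower number from compound 1 to compound 2 (1.09 log units; beyond the scatter). It is large and beyond the scatter, and it also alters the group on the amide-type nitrogen. It is a different substitution, however, so it shows only that this part of the molecule can move the number and sets no direction for the new group. In this assay the expected step is smaller and towards a lower number: a 2.7-fold lower number from compound 2 to compound 3 (0.42 log units; beyond the scatter). The range is wide enough to include no change. For compound 3 the estimated value is 200 nM, with an expected range of 40 nM to 1000 nM.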

Compound 3, concentration for 50% growth inhibition: 4170 nM
Beside the measured number, compound 3's estimate is 21-fold (1.32 log units) below it, outside the stated range (above it).
By their numbers in this assay, from the lowest: compound 2; then compounds 3 and 1 (each within the scatter of the next).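

In this assay, replacing methyl with (4-methylpiperidin-1-yl)methyl gives a 7.9-fold higher number from compound 2 to compound 3 (0.90 log units; beyond the scatter) and so weakens inhibition of growth. The earlier step concerned the whole group on the amide-type nitrogen, whereas this one shows that a single change on the saturated chain carbon bound to an aromatic carbon can also move the number beyond the scatter, here in the unfavourable direction. No measurement shown accounts for this step.

As far as these compounds go, with only methyl and (4-methylpiperidin-1-yl)methyl compared at this place, it remains open whether the rise belongs to the piperidine ring, its 4-methyl group or the size of the entering group. Piperidin-1-ylmethyl, morpholin-4-ylmethyl, 4-methylpiperazin-1-ylmethyl and dimethylaminomethyl would each test a different part of that question.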